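A few compounds are considered here, and "the series" means these few. Any claim that something is new, unique, unknown or untested is made for them only; others in the source may bear on it.

Notes on the series. For the measured compounds named here, compound 1 `Cc1ccc(OCC(=O)N(Cc2cccs2)c2ccn(C)n2)cc1` in an assay on HEK293 cells for agonist activity at transient receptor potential cation channel subfamily M member 8 (Homo sapiens), read by fluorescence and calcium flux, with a stated time of 15 min (a higher number here means that more compound is needed for the effect, a lower number that less compound is needed), gives 855 nM, the only numerical reading in the set so far. Compound 2 `CCN(Cc1cc[nH]n1)C(=O)COc1ccc(C)cc1` keeps the shared core of compound 1 but carries an ethyl group and a (1H-pyrazol-3-yl)methyl group on the amide-type nitrogen. In this assay compound 2 is reported as "not active" (no number reported); there is therefore no single number on which compound 2 stands, only the statement that no effect was recorded. Compound 3 `CCN(Cc1ccccn1)C(=O)COc1ccc(C)cc1` is the next step from compound 2: pyridin-2-yl in place of 1H-pyrazol-3-yl on a saturated chain carbon bound to an amide-type nitrogen. With no number for compound 2 the step cannot be measured against a reading, and no pattern from a single pair can be claimed. The expectation is that compound 3 remains weak in this assay, at best on the order of compound 1, and that a fair chance exists of it again being reported without a number. For compound 3 in this assay the estimated value is 5000 nM, with an expected range from 1200 nM to 30000 nM.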

Compound 3, half-maximal effective concentration: 16000 nM
Beside the measured number, compound 3's estimate is 3.2-fold (0.51 log units) below it; measured number inside the range.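

No step can be read from compound 2 to compound 3: in this assay compound 2 has no number, while compound 3 gives 16000 nM. No further data bear on this result. The compounds shown leave open how large any difference in this assay between (1H-pyrazol-3-yl)methyl and (pyridin-2-yl)methyl would be.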